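This account rests on a few compounds, and the source may have more. Where it says the series, first, only, none or still open, it means among the compounds named here.

Measured so far:
compound 1, `C(=C/c1nn2c(-c3ccncc3)nnc2s1)\c1ccco1`: 54%
compound 2, `C(=C/c1nn2c(-c3ccccc3)nnc2s1)\c1ccco1`: 79.4%

For the measured compounds named here, in an assay for inhibition of histone-lysine N-methyltransferase, H3 lysine-79 specific (Homo sapiens), read by scintillation counting, with stated times of 15 min and 60 min, tested at 25 uM, in the presence of a further agent that is not named here (a lower number here means a weaker effect, a higher number a stronger effect of the compound at the concentration tested), compound 2 holds the higher of the two numbers; the single measured step is a number 25.4 percentage points higher from compound 1 to compound 2 (beyond the scatter). Compound 3, `CN(C)c1ccc(-c2nnc3sc(/C=C/c4ccco4)nn23)cc1`, differs from compound 2 by dimethylamino in place of hydrogen on an aromatic carbon. Going by the values given here, the one measured step exchanges the aryl ring itself and says nothing direct about a substituent added to that ring, so it bears on this change only loosely. A small move, within or near the scatter, is therefore expected, a number 4.4 percentage points lower from compound 2 to compound 3 (within the scatter). For compound 3 the estimate in this assay is 75%, with a range from 55% to 92%.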

Compound 3, a percentage reported as inhibition, at one concentration (the size of the read-out at that concentration, not a potency): 56%
Compound 3: the middle estimate sits 19 percentage points above what was measured; the range from low to high includes it.
By their numbers in this assay, from the lowest: compounds 1 and 3 (each within the scatter of the next); then compound 2.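

In this assay, dimethylamino in place of hydrogen on an aromatic carbon, para to a large group, gives a number 23.4 percentage points lower from compound 2 to compound 3 (beyond the scatter). The earlier step exchanged the aryl ring itself; this one shows that the read-out also responds to a substituent on the phenyl ring, with the core unchanged. A single substituent at this place is therefore enough to produce a step beyond the scatter, and here it goes downward.

As far as these compounds go, whether methoxy, fluorine or a primary amine at the same place would follow dimethylamino remains open. Nothing shown accounts for the step.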